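The source may report more compounds than this note shows. Statements on the series, on what has been measured and on what is new or still open speak of the compounds shown alone.

Measured so far in a functional assay (trachea) with Rattus norvegicus as the target; a lower number here means a less potent compound, a higher number a more potent compound, by a factor of ten per unit of this negative logarithm:
compound 1 `CC1(C)C=C(n2ccccc2=O)c2ccccc2O1` gives 5.05
compound 2 `CC(=O)c1ccc2c(c1)C(n1ccccc1=O)=CC(C)(C)O2` gives 6.65
compound 3 `COc1ccc(C(=O)c2ccc3c(c2)C(n2ccccc2=O)=CC(C)(C)O3)cc1` gives 5.72

Compound 3 stands second highest of these three numbers: compound 1 lies nearer to it on the low side, compound 2 further from it on the high side.

Compound 4 `CC1(C)C=C(n2ccccc2=O)c2cc(C(=O)c3cccs3)ccc2O1` differs from compound 3 by thiophen-2-yl in place of 4-methoxyphenyl on a carbonyl carbon. The step that bears most directly on this place is a number 0.93 log units lower from compound 2 to compound 3 (beyond the scatter), in which the carbonyl carbon changed from carrying methyl to carrying the larger aryl group. The other step, a number 1.60 log units higher from compound 1 to compound 2 (beyond the scatter), concerns acetyl entering on the aromatic carbon and is less closely related. For the measured compounds named here, no measured pair compares two different aromatic groups on this carbonyl carbon, so the direction is uncertain. The entering group is the smaller of the two by the count given, which puts compound 4 somewhere between the methyl ketone and the methoxyphenyl ketone; a small upward step is expected, a number 0.23 log units higher from compound 3 to compound 4 (within the scatter), though a result within the scatter would not surprise. Compound 4 is therefore estimated at 5.95 in this assay, with a range of 5.35 to 6.55.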

Compound 4, logarithm of the reciprocal of the active concentration, log(1/C): 5.84
Compound 4: the middle estimate sits 0.11 log units above what was measured, and the stated range covers the measured number.
By their numbers in this assay, from the lowest: compound 1; then compounds 3 and 4 (each within the scatter of the next); then compound 2.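

In this assay thiophen-2-yl on the carbonyl carbon gives a number 0.12 log units higher from compound 3 to compound 4 (within the scatter) and so cannot be told apart from 4-methoxyphenyl there, despite the five-membered ring with one sulfur hetero atom in place of the six-membered ring of carbon only. Replacing methyl on this carbon with thiophen-2-yl gives a number 0.81 log units lower from compound 2 to compound 4 (beyond the scatter) and so shows, with a second ring type, the same direction as a number 0.93 log units lower from compound 2 to compound 3 (beyond the scatter) on the same carbon. The aromatic ketone still keeps a clear margin over hydrogen on the aromatic carbon, with a number 0.79 log units higher from compound 1 to compound 4 (beyond the scatter) for the whole (thiophen-2-yl)carbonyl group.

As far as these compounds go, what separates methyl from the two aromatic groups stays open, and no measurement at hand speaks to it.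
Also open, from the compounds shown here alone, is whether an ethyl group or a longer chain on the carbonyl carbon, or an amine on the aromatic group, would read with compound 2 or with compound 4.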